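Swapping the Methylpiperazine Amide Ring for Piperidine

The compounds below may be only part of what the source reports. "The series", "measured", "known", "first", "only" and "open" are said of these compounds alone.

Of the compounds shown here, three sharing one core have been tested in a functional assay on PC-3 cells (Homo sapiens) for inhibition, read by sulforhodamine B assay, with a stated time of 72 h; a lower number here means a stronger inhibitor, a higher number a weaker inhibitor. Compound 1 `CCOC(=O)Nc1sc(-c2ccc(Cl)cc2)c(-c2ccc(Cl)cc2)c1C(=O)NC1CC1` gives 27600 nM, compound 2 `Nc1sc(-c2ccc(Cl)cc2)c(-c2ccc(Cl)cc2)c1C(=O)NC1CCCC1` gives 21200 nM, and compound 3 `CN1CCN(C(=O)c2c(N)sc(-c3ccc(Cl)cc3)c2-c2ccc(Cl)cc2)CC1` gives 13100 nM. Compound 3 thus stands at the lowest of the three numbers: its nearest neighbour is compound 2, a gap within the scatter, while compound 1 lies beyond it. Compound 4 `Nc1sc(-c2ccc(Cl)cc2)c(-c2ccc(Cl)cc2)c1C(=O)N1CCCCC1` differs from compound 3 by piperidin-1-yl in place of 4-methylpiperazin-1-yl on a carbonyl carbon. Going by the values given here, the only measured step at the same carbonyl carbon is a 1.6-fold lower number from compound 2 to compound 3 (0.21 log units; within the scatter), which stayed within the scatter. Exchanging one ring for another there is therefore expected to move this assay little, giving a step of a 1.2-fold higher number from compound 3 to compound 4 (0.09 log units; within the scatter). Compound 4 is estimated at 16000 nM, within a range from 7000 nM to 40000 nM.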

Compound 4, half-maximal inhibitory concentration: 14300 nM
Compound 4: middle estimate off by 1.1-fold (0.05 log units), on the high side, and the stated range covers the measured number.
By their numbers in this assay, from the lowest: compounds 3, 4, 2 and 1 (each within the scatter of the next, the first and the last beyond it).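

In this assay, the step of a 1.1-fold higher number from compound 3 to compound 4 (0.04 log units; within the scatter) shows that piperidin-1-yl on this carbonyl carbon reads the same as 4-methylpiperazin-1-yl, and the step of a 1.5-fold lower number from compound 2 to compound 4 (0.17 log units; within the scatter) shows the same against cyclopentylamino. Going by these compounds alone, the three groups at this carbonyl carbon, on compounds 2, 3 and 4, thus all lie within the scatter of one another, with no compound among them going against this. Nothing measured here offers an explanation for this. What the compounds shown leave open is whether a morpholine ring, an open-chain diethylamino group or a carboxylic acid at this carbonyl carbon would also leave the number unmoved.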